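Cyclopentyl in Place of Isobutyl on a Shared Core

A few compounds are considered here, and "the series" means these few. Any claim that something is new, unique, unknown or untested is made for them only; others in the source may bear on it.

Compound 3 `COc1cc2nc(CC(C)C)nc(N3CCN(c4ccccc4OC)CC3)c2cc1OC` was tested in an in vitro assay on U2OS cells for agonist activity at neurotensin receptor type 2 (Homo sapiens), read by reporter gene assay and beta-arrestin recruitment; a higher number here means that more compound is needed for the effect, a lower number that less compound is needed. In this assay compound 3 gives only a limit of the assay, > 80000 nM. Compound 1 `COc1cc2nc(C)nc(N3CCN(c4ccccc4OC)CC3)c2cc1OC` likewise gives only a limit, > 80000 nM. Compound 2 `CCc1nc(N2CCN(c3ccccc3OC)CC2)c2cc(OC)c(OC)cc2n1` again gives only a limit, > 80000 nM. Compound 3 therefore stands at the limit of > 80000 nM in this assay, at which 3 of the 3 values shown sit, and the steps a step that the two limits leave unreadable from compound 1 to compound 2, a step that the two limits leave unreadable from compound 1 to compound 3 and a step that the two limits leave unreadable from compound 2 to compound 3 carry no readable size. Compound 4 `COc1cc2nc(C3CCCC3)nc(N3CCN(c4ccccc4OC)CC3)c2cc1OC` differs from compound 3 by cyclopentyl in place of isobutyl on an aromatic carbon, a cyclopentyl in place of isobutyl on an aromatic carbon. Among the measured compounds shown here, none of the measured steps bears on this change, so no direction beyond the scatter can be read from them. The expected step is a step that the limit leaves unreadable from compound 3 to compound 4. The estimate for compound 4 is 100000 nM, with a range from 30000 nM to 400000 nM.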

Compound 4, half-maximal effective concentration: > 80000 nM
Compound 4 was reported as a limit (the forecaster's own chance of this, stated with the estimate: 85%); the middle value is on the limit's open side.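

Compound 4 gives only a limit in this assay, as do compound 1, compound 2 and compound 3, so no step to compound 4 can be read: the limit of > 80000 nM in this assay, at which 4 of the 4 values shown sit.

The compounds shown leave open how much of each the effect requires, and whether changing this group on the shared core alters that amount.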